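Methyl in place of fluoro: expected clearance of compound 3

A few compounds are considered here, and "the series" means these few. Any claim that something is new, unique, unknown or untested is made for them only; others in the source may bear on it.

Of the compounds shown here, two have so far been measured in an in vitro ADME assay on microsomes from liver (Mus musculus) for pharmacokinetics, read by LC-MS, with a stated time of 10 min, tested at 1 uM (a higher number here means faster removal of the compound, a lower number slower removal), on this shared core. Among the measured compounds shown here, compound 1 `CC(C)c1ccc(NC(=O)[C@H]2CN(C)C[C@@H]2c2ccc(/C=C/C(=O)Nc3ccccc3N)cc2)cc1` gives 54 mL/min/kg there and compound 2 `CN1C[C@H](C(=O)Nc2cccc(F)c2)[C@@H](c2ccc(/C=C/C(=O)Nc3ccccc3N)cc2)C1` gives 56 mL/min/kg in the same test, so compound 2 stands within the scatter of its only measured neighbour.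

Compound 3 `Cc1cccc(NC(=O)[C@H]2CN(C)C[C@@H]2c2ccc(/C=C/C(=O)Nc3ccccc3N)cc2)c1` follows from compound 2 through a single change methyl in place of fluoro on an aromatic carbon that puts methyl in place of fluoro on an aromatic carbon, meta to a large group. For the measured compounds named here, only one measured step bears on it, a different exchange on the same amide-type nitrogen that brought in the 3-fluorophenyl group. Going by the values given here, that step was a 1.0-fold higher number from compound 1 to compound 2 (0.02 log units; within the scatter) and offers the only guide, so no shift beyond the scatter is expected from the smaller swap, though one step is thin support.

Estimated on this basis, the expected change is no change at the digits printed from compound 2 to compound 3 (within the scatter) and thus none beyond the scatter. The estimate for compound 3 is an expected clearance of 56 mL/min/kg with a range of 36 mL/min/kg to 85 mL/min/kg for the measurement still to come.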

Compound 3, clearance: 74 mL/min/kg
The estimate for compound 3 lay 1.3-fold (0.12 log units) below the measured number; the measured number falls inside the stated range.
By their numbers in this assay, from the lowest: compounds 1, 2 and 3 (each within the scatter of the next).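

In this assay, this position on the six-membered aromatic ring, the first on which a single small group has been exchanged, shows a 1.3-fold higher number from compound 2 to compound 3 (0.12 log units; within the scatter) when methyl takes the place of fluoro. Neither group sets compound 2 and compound 3 apart beyond the scatter, and the wider exchange of 4-isopropylphenyl for 3-methylphenyl on the amide-type nitrogen likewise gives a 1.4-fold higher number from compound 1 to compound 3 (0.14 log units; within the scatter), so the three compounds shown cannot be ordered in this test and none of these exchanges separates the compounds on clearance. Nothing among the data shown speaks to what underlies these numbers.

The compounds shown leave open how this assay would read with an amine, a carboxylic acid or a longer chain at this place, groups of a different kind from the single-atom methyl and fluoro compared here. They also leave open whether a group other than a substituted phenyl on the amide-type nitrogen, such as a plain alkyl chain or a pyridine, would move clearance beyond the scatter on the shared core.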